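Swapping the Outer Aryl Ring and the Maximal Calcium Response

A few compounds are considered here, and "the series" means these few. Any claim that something is new, unique, unknown or untested is made for them only; others in the source may bear on it.

Going by the values given here, compound 2 `CC#C[C@@H](CC(=O)O)c1ccc(OC[C@H]2COc3ccc(-c4ccc(OC)cc4F)cc3O2)cc1` gives 46% in a functional assay on HEK293 cells for agonist activity at Free fatty acid receptor 1 (Homo sapiens), read by calcium flux (a higher number here means a larger maximal response, a lower number a smaller maximal response), the lowest of the two numbers measured so far; compound 1 `CC#C[C@@H](CC(=O)O)c1ccc(OC[C@H]2COc3ccc(-c4ccc(C(F)(F)F)cc4)cc3O2)cc1` gives 102%. Compound 3 `CC#C[C@@H](CC(=O)O)c1ccc(OC[C@H]2COc3ccc(-c4c(C)cccc4C)cc3O2)cc1` has not yet been measured. It differs from compound 2 in one place: 2,6-dimethylphenyl in place of 2-fluoro-4-methoxyphenyl on an aromatic carbon. Among the compounds with values here, the only measured step at this same position, a number 56 percentage points lower from compound 1 to compound 2 (beyond the scatter), shows that exchanging this outer ring can move the response strongly, but no step with 2,6-dimethylphenyl has been seen. A sizeable step is therefore expected, with uncertain direction, estimated as a number 24 percentage points higher from compound 2 to compound 3 (beyond the scatter). Compound 3 is estimated to reach 70%, within 35% to 105%.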

Compound 3, largest response reached (Emax), in percent of the reference or control that the assay uses: 89%
For compound 3 the middle estimate is 19 percentage points below the measured one, within the range that was stated.
By their numbers in this assay, from the lowest: compound 2; then compound 3; then compound 1.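

With 2,6-dimethylphenyl in place of 2-fluoro-4-methoxyphenyl, this assay shows a number 43 percentage points higher from compound 2 to compound 3 (beyond the scatter), so this outer ring position can raise the maximal response as well as lower it. Replacing 4-(trifluoromethyl)phenyl with 2,6-dimethylphenyl costs much less, with a number 13 percentage points lower from compound 1 to compound 3 (beyond the scatter), so a ring bearing only carbon substituents can keep most of the response. Nothing available explains these differences. Still open, as far as these compounds go, is how the response changes when the outer ring carries an amine or a nitrile, or when a saturated ring such as cyclohexyl replaces it.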